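A few compounds are considered here, and "the series" means these few. Any claim that something is new, unique, unknown or untested is made for them only; others in the source may bear on it.

Measured compounds:
Compound 1, `CCc1ccc(-c2nc3c(c(C)nn3-c3ccccc3)c(-c3ccccc3)c2C#N)cc1`: in an ADME assay on BJ cells (Homo sapiens) for cytotoxicity, with a stated time of 72 h (a higher number here means that more compound is needed for the effect, a lower number that less compound is needed), compound 1 gives > 20000 nM, which is a limit of the assay and not a number.
Compound 2, `CCc1ccc(-c2nc3c(c(C)nn3-c3ccccc3)c(-c3ccc(O)cc3)c2C#N)cc1`: compound 2 gives > 20000 nM, again a limit.
Compound 3, `Cc1cccc(-c2nc3c(c(C)nn3-c3ccccc3)c(-c3ccccc3O)c2C#N)c1`: compound 3 gives > 20000 nM, once more a limit.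

Among the compounds with values here, because all three values sit at the same limit (the limit of > 20000 nM in this assay, at which 3 of the 3 values shown sit), the only step between compounds that differ in one place, a step that the two limits leave unreadable from compound 1 to compound 2, cannot be read in size or direction. Compound 3 therefore stands nowhere on a numerical scale in this assay; all that is known of it is that its value is a limit, as it is for the two other measured compounds.

Compound 4, `Cc1nn(-c2ccccc2)c2nc(-c3ccc(S(C)(=O)=O)cc3)c(C#N)c(-c3ccccc3O)c12`, differs from compound 3 by 4-(methylsulfonyl)phenyl in place of 3-methylphenyl on an aromatic carbon. Within the data shown here, no measured step involves this change, and the single measured step between compound 1 and compound 2, though it also touches a phenyl substituent, is itself unreadable. On the data shown, no step beyond the scatter can be expected for a step that the limit leaves unreadable from compound 3 to compound 4, and the most likely outcome is that compound 4 again returns a limit. Compound 4 is accordingly estimated at 25000 nM, with a range from 10000 nM to 60000 nM.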

Compound 4, half-maximal effective concentration: > 20000 nM
Compound 4 gave a limit, no number; the forecaster's own chance of this, stated with the estimate: 80%; the middle value does not contradict the limit.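

In this assay compound 4 gives > 20000 nM, which is a limit of the assay and not a number. Compound 3 carries the same limit, so no step between compound 3 and compound 4 can be read: the limit of > 20000 nM in this assay, at which 4 of the 4 values shown sit.

The compounds shown leave open whether any change to the shared core would give a readable number in this assay.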